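From bromo to hydroxy on the aromatic ring

The source may hold more compounds than are shown below. What is called first, only, known or untested is meant among the compounds shown, and "the series" means these compounds.

In a functional assay on SW-620 cells (Homo sapiens) for inhibition, read by MTT assay, with a stated time of 72 h (on this read-out higher numbers stand for weaker inhibition and lower numbers for stronger inhibition), compound 1 (`COc1cc(NC(C)CCCNC(=O)NNC(=O)Nc2ccc(Br)cc2)c2ncccc2c1`) gives 17000 nM and compound 2 (`COc1cc(NC(C)CCCNC(=O)NNC(=O)Nc2cc(C(F)(F)F)cc(C(F)(F)F)c2)c2ncccc2c1`) gives 16000 nM in a pair of values that lie within the scatter of each other. Compound 3 (`COc1cc(NC(C)CCCNC(=O)NNC(=O)Nc2ccc(O)cc2)c2ncccc2c1`) is still unmeasured and carries hydroxy in place of bromo on an aromatic carbon, para to a large group (hydroxy in place of bromo on an aromatic carbon). Among the compounds with values here, no measured step shows this change. The expected move is small and toward weaker inhibition, estimated as a 1.4-fold higher number from compound 1 to compound 3 (0.15 log units; within the scatter) in this assay and likely to stay within the scatter. Compound 3 is expected to reach 24000 nM within a range from 9000 nM to 65000 nM on this estimate.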

Compound 3, half-maximal inhibitory concentration: > 100000 nM
Compound 3: no number, only a limit; the forecaster's own chance of this, stated with the estimate: 20%; middle value at least 4.1-fold (0.61 log units) from the limit.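

Hydroxy in place of bromo on this aromatic carbon, para to a large group, gives the first step beyond the scatter in this assay: an at least 5.8-fold higher number from compound 1 to compound 3 (0.76 log units; beyond the scatter). Compound 3 gives > 100000 nM, which is a limit of the assay and not a number. The true size of the step therefore stays unknown: the limit of > 100000 nM in this assay, at which 1 of the 3 values shown sits.

The compounds shown leave open whether weaker inhibition follows from hydroxy alone or from other replacements on this carbon as well. A methoxy group, an amine or a carboxylic acid at the same place would bear on that.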